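The source may report more compounds than this note shows. Statements on the series, on what has been measured and on what is new or still open speak of the compounds shown alone.

Measured so far in a functional assay on MCF7 cells (Homo sapiens) for antiproliferative activity, read by sulforhodamine B assay, with a stated time of 48 h; a higher number here means a weaker inhibitor, a lower number a stronger inhibitor:
compound 1 `CCCCCC(=O)Nc1ccc(S(=O)(=O)Oc2ccccc2I)cc1`: 10000 nM
compound 2 `CCNC(=O)Nc1ccc(S(=O)(=O)Oc2ccccc2I)cc1`: 1100 nM

For the measured compounds named here, compound 2 holds the lower of the two numbers; the only other compound, compound 1, lies a 9.1-fold lower number from compound 1 to compound 2 (0.96 log units; beyond the scatter) away, and that gap is beyond the scatter.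

Compound 3 `O=C(Nc1ccc(S(=O)(=O)Oc2ccccc2I)cc1)NC1CC1` differs from compound 2 by cyclopropyl in place of ethyl on an amide-type nitrogen. Going by the values given here, the single measured step, a 9.1-fold lower number from compound 1 to compound 2 (0.96 log units; beyond the scatter), exchanges the group on the carbonyl carbon itself, pentyl for ethylamino, so it speaks to the amide-to-urea switch and not to the substituent on the urea nitrogen. No measured pair tests ethyl against cyclopropyl on that nitrogen, so the step to compound 3 cannot be anchored to a shown step. With nothing to point either way, the expected step is a 1.2-fold lower number from compound 2 to compound 3 (0.09 log units; within the scatter), within the scatter. The estimate for compound 3 in this assay is therefore 900 nM, with a range from 350 nM to 2500 nM.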

Compound 3, half-maximal inhibitory concentration: 7400 nM
The estimate for compound 3 lay 8.2-fold (0.91 log units) below the measured number, outside the stated range (above it).
By their numbers in this assay, from the lowest: compound 2; then compounds 3 and 1 (each within the scatter of the next).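

Changing the group on the amide-type nitrogen is not a neutral exchange: in this assay, cyclopropyl in place of ethyl gives a 6.7-fold higher number from compound 2 to compound 3 (0.83 log units; beyond the scatter), beyond the scatter. The gain seen for ethylamino over pentyl on the carbonyl carbon, a 9.1-fold lower number from compound 1 to compound 2 (0.96 log units; beyond the scatter), therefore does not carry over to every urea, since cyclopropylamino in place of pentyl gives only a 1.4-fold lower number from compound 1 to compound 3 (0.13 log units; within the scatter), within the scatter. Nothing available explains this sensitivity to the nitrogen substituent.

Going by these compounds, whether the loss follows the ring itself or the added carbon remains open; isopropyl or propyl on the same nitrogen would help to separate the two. The compounds shown also leave open how methyl or a longer straight chain would fare at this position.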